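Chloro on the sulfonyl aryl ring of a cyclic urea series

The source may report more compounds than this note shows. Statements on the series, on what has been measured and on what is new or still open speak of the compounds shown alone.

Compound 1 `O=C1NC(c2ccccc2)CN1S(=O)(=O)c1ccccc1` and compound 3 `Cc1ccc(C2CNC(=O)N2S(=O)(=O)c2ccccc2)cc1` carry the same shared core; how their two cores differ is not broken down here. In a functional assay on A549 cells (Homo sapiens) for cytotoxicity (a higher number here means a weaker inhibitor, a lower number a stronger inhibitor), compound 1 gives 145000 nM and compound 3 gives 157000 nM; the two numbers lie within the scatter of each other, so nothing separates them. Compound 2 `O=C1NC(c2ccccc2)CN1S(=O)(=O)c1ccc(Cl)cc1` arises from compound 1 by the change (chloro in place of hydrogen on an aromatic carbon); in this assay compound 2 gives 9470 nM, a step of a 15-fold lower number from compound 1 to compound 2 (1.19 log units; beyond the scatter). Compound 4 `Cc1ccc(C2CNC(=O)N2S(=O)(=O)c2ccc(Cl)cc2)cc1` arises from compound 3 by chloro in place of hydrogen on an aromatic carbon; the place of the change reads the same way as in the pair before it, so this is the same change made a second time on a different core.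

The expectation for compound 4 rests on that single measured step: because compound 1 to compound 2 moved by a 15-fold lower number from compound 1 to compound 2 (1.19 log units; beyond the scatter), compound 4 is expected to sit below compound 3 by a step of about a 13-fold lower number from compound 3 to compound 4 (1.12 log units; beyond the scatter) in this assay. Going by the values given here, only one instance of the change is measured, so the estimate is given with a broad range. Compound 4 is estimated at 12000 nM in this assay, between 4000 nM and 40000 nM.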

Compound 4, half-maximal inhibitory concentration: 266000 nM
Compound 4: the middle estimate sits 22-fold (1.35 log units) below what was measured, and the stated range ends below it.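

In this assay, phenyl to 4-chlorophenyl on the core of compound 3 gives a 1.7-fold higher number from compound 3 to compound 4 (0.23 log units; within the scatter) and so leaves nothing that separates compound 4 from compound 3. The large step seen with the same change on the core of compound 1 therefore does not carry over to the core of compound 3, and the two steps differ by more than their scatter allows: the same change on two cores in this assay, a 15-fold lower number (1.19 log units; beyond the scatter) from compound 1 to compound 2 and a 1.7-fold higher number (0.23 log units; within the scatter) from compound 3 to compound 4, 26-fold (1.41 log units) apart, beyond the scatter of two such steps. This shows that, in this series, the effect of the chloro depends on the core that carries it, so a step measured on one core cannot be transferred to the other; it does not show why the two cores respond differently, and with a single pair on each core it gives no rule for any further core.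

The compounds shown leave open whether a bromo, a methoxy or a nitrile in place of the chloro would also give a large step on the core of compound 1 and none on the core of compound 3. They also leave open whether a more strongly differing group, such as an amine or a carboxylic acid at the same place, would bring the two cores into line.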